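Notes on the sulfonyl substituent of compound 3

A few compounds are considered here, and "the series" means these few. Any claim that something is new, unique, unknown or untested is made for them only; others in the source may bear on it.

Of the compounds shown here, three have been measured in a functional assay on CHO.K1 cells for antagonist activity at prostaglandin D2 receptor 2 (Homo sapiens), read by GTPgammaS binding, with a stated time of 1 h; a higher number here means a weaker inhibitor, a lower number a stronger inhibitor. Compound 1 `CNC(=O)c1ccc(Cc2c3c(n(CC(=O)O)c2C)CCNC3=O)c(S(=O)(=O)c2ccccc2)c1` gives 10 nM; compound 2 `COc1ccc(S(=O)(=O)c2ccccc2)c(Cc2c3c(n(CC(=O)O)c2C)CCNC3=O)c1` gives 3.6 nM; compound 3 `Cc1c(Cc2ccccc2S(=O)(=O)c2cccc(Cl)c2)c2c(n1CC(=O)O)CCNC2=O` gives 4 nM. Compound 3 holds the second highest of the three numbers: its value and that of compound 2 lie within the scatter of each other, while compound 3 gives a lower number than compound 1, a gap beyond the scatter. Compound 4 `Cc1c(Cc2ccccc2S(=O)(=O)N(C)Cc2ccccc2)c2c(n1CC(=O)O)CCNC2=O` is not yet measured. It differs from compound 3 in one place: benzyl(methyl)amino in place of 3-chlorophenyl on a sulfonyl sulfur. For the measured compounds named here, no measured pair shows the effect of this change, so its direction rests on judgment alone. A small step toward a higher number is expected, a 3.8-fold higher number from compound 3 to compound 4 (0.57 log units; beyond the scatter), with a wide range around it. Compound 4 is estimated at 15 nM, between 3 nM and 80 nM.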

Compound 4, half-maximal inhibitory concentration: 26 nM
Compound 4: the middle estimate sits 1.7-fold (0.24 log units) below what was measured; the range from low to high includes it.
By their numbers in this assay, from the lowest: compounds 2 and 3 (each within the scatter of the next); then compound 1; then compound 4.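

Read directly, benzyl(methyl)amino in place of 3-chlorophenyl on a sulfonyl sulfur gives a 6.5-fold higher number from compound 3 to compound 4 (0.81 log units; beyond the scatter) in this assay, the only pair shown that isolates this position. The group on the sulfonyl sulfur therefore affects the read-out, although compound 4 still gives 26 nM. No supporting measurement bears on this step.

Still open, from the compounds shown here alone, is whether the change depends on the aromatic ring of the benzyl group or on the nitrogen attached to the sulfur. A dimethylamino group or a piperidine on the sulfonyl sulfur would help separate these two readings.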